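Methoxy to methylsulfanyl in the peptide epoxyketone series

A few compounds are considered here, and "the series" means these few. Any claim that something is new, unique, unknown or untested is made for them only; others in the source may bear on it.

- compound 1 `CSC[C@H](NC(=O)c1cc(C)on1)C(=O)N[C@@H](CSC)C(=O)N[C@@H](CC(C)C)C(=O)[C@@]1(C)CO1`: 0.132 h
- compound 2 `COC[C@H](NC(=O)c1cc(C)on1)C(=O)NCC(=O)N[C@@H](CC(C)C)C(=O)[C@@]1(C)CO1`: 1.86 h

In an ADME assay on microsomes from liver (Rattus norvegicus) for metabolic stability (a higher number here means that the compound lasts longer, a lower number that the compound disappears faster), compound 2 stands higher of the two at 1.86 h, beyond the scatter from compound 1. Compound 3 `CSC[C@H](NC(=O)c1cc(C)on1)C(=O)NCC(=O)N[C@@H](CC(C)C)C(=O)[C@@]1(C)CO1` differs from compound 2 by methylsulfanyl in place of methoxy on a saturated chain carbon, two bonds along the chain from an amide-type nitrogen and a carbonyl carbon. For the measured compounds named here, no measured pair isolates this change. Compound 1 also holds methylsulfanyl and gives 0.132 h, so a fall beyond the scatter is expected, though a smaller one than that gap. The expected move is a 3.1-fold lower number from compound 2 to compound 3 (0.49 log units; beyond the scatter). For compound 3 the estimate is 0.6 h, with an expected range of 0.2 h to 1.5 h.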

Compound 3, half-life: 0.373 h
Estimate against measurement, compound 3: 1.6-fold (0.21 log units) above; low and high end bracket the measured number.
By their numbers in this assay, from the lowest: compound 1; then compound 3; then compound 2.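

In this assay, methylsulfanyl in place of methoxy on this saturated chain carbon now has its own measured pair, giving a 5.0-fold lower number from compound 2 to compound 3 (0.70 log units; beyond the scatter). Hydrogen in place of (methylsulfanyl)methyl on the saturated chain carbon bound to an amide-type nitrogen and a carbonyl carbon can also be read alone, giving a 2.8-fold higher number from compound 1 to compound 3 (0.45 log units; beyond the scatter), so in these compounds the number falls with methylsulfanyl at either place. Nothing available explains either step. As far as these compounds go, how ethoxy or hydroxyl on the first of these carbons would compare with methoxy remains open.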